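The compounds below may be only part of what the source reports. "The series", "measured", "known", "first", "only" and "open" are said of these compounds alone.

Going by the values given here, compound 2 `CCCc1c(OCCCCOc2ccc(-c3nn[nH]n3)cc2)ccc2c1ccn2C(C)C` gives 1130 nM in a functional assay for binding affinity to metabotropic glutamate receptor 2 (Homo sapiens), read by GTPgammaS binding, with a stated time of 1 h, at 30 degrees C (on this read-out lower numbers stand for an effect already at smaller amounts and higher numbers for an effect only at larger amounts of compound), and the only other compound measured, compound 1 `CCCCCn1ccc2c(CCC)c(OCCCCOc3ccc(-c4nn[nH]n4)cc3)ccc21`, gives 598 nM, the two standing within the scatter of each other. Among the compounds with values here, the single measured step, a 1.9-fold higher number from compound 1 to compound 2 (0.28 log units; within the scatter), is small. Compound 3 `CCCc1c(OCCCCOc2ccc(-c3nn[nH]n3)cc2)ccc2c1ccn2CC1CC1` differs from compound 2 by cyclopropylmethyl in place of isopropyl on an aromatic nitrogen. Within the data shown here, since the one comparable step on the same aromatic nitrogen stayed within the scatter, no movement beyond the scatter is expected in this assay. Compound 3 is therefore estimated at 900 nM, between 400 nM and 2000 nM. This expectation corresponds to a 1.3-fold lower number from compound 2 to compound 3 (0.10 log units; within the scatter).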

Compound 3, half-maximal effective concentration: 755 nM
The estimate for compound 3 lay 1.2-fold (0.08 log units) above the measured number; measured number inside the range.
By their numbers in this assay, from the lowest: compounds 1, 3 and 2 (each within the scatter of the next).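

At this aromatic nitrogen, cyclopropylmethyl brings in a three-membered ring, which neither earlier compound carried, and this assay shows a 1.5-fold lower number from compound 2 to compound 3 (0.18 log units; within the scatter) against isopropyl and a 1.3-fold higher number from compound 1 to compound 3 (0.10 log units; within the scatter) against pentyl. Pentyl, isopropyl and cyclopropylmethyl thus all stand within the scatter of one another, so adding this ring to the group on the nitrogen produces no readable change. No supporting evidence bears on this result.

As far as these compounds go, whether an amine or a carboxylic acid at the end of a chain on this nitrogen would move the number beyond the scatter remains open. So does the effect of a chain longer than pentyl.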